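Swapping a urea for an acetyl group on the amine

The source may report more compounds than this note shows. Statements on the series, on what has been measured and on what is new or still open speak of the compounds shown alone.

Of the compounds shown here, three sharing one core have been tested in a functional assay on the whole organism (artery) for inhibition, with Rattus norvegicus as the target, at a dose of 3 mg/kg by the intraduodenal route; on this read-out lower numbers stand for less inhibition and higher numbers for more inhibition at the one dose given (going by the name of the read-out). Compound 1 `CCCCc1ccc(CNS(=O)(=O)c2ccccc2)c(=O)n1Cc1ccc(-c2ccccc2-c2nn[nH]n2)cc1` carries a phenylsulfonyl group on the amine nitrogen and gives 25.2%. Compound 2 `CCCCc1ccc(CN)c(=O)n1Cc1ccc(-c2ccccc2-c2nn[nH]n2)cc1` carries hydrogen there and gives 2.8%. Compound 3 `CCCCc1ccc(CNC(=O)NC2CCCCC2)c(=O)n1Cc1ccc(-c2ccccc2-c2nn[nH]n2)cc1` carries cyclohexylcarbamoyl there and gives 0%, which makes compound 3 the lowest of the three; its nearest neighbour is compound 2, the gap within the scatter, and its furthest is compound 1, a number 25.2 percentage points lower from compound 1 to compound 3 (beyond the scatter).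

Compound 4 `CCCCc1ccc(CNC(C)=O)c(=O)n1Cc1ccc(-c2ccccc2-c2nn[nH]n2)cc1` is not yet measured. It differs from compound 3 in one place: methyl in place of cyclohexylamino on a carbonyl carbon. Within the data shown here, two steps bear on this. Going a number 2.8 percentage points lower from compound 2 to compound 3 (within the scatter), the change from hydrogen to the urea left the read-out within the scatter. Going a number 25.2 percentage points lower from compound 1 to compound 3 (beyond the scatter) was the only change of real size, and it involved the phenylsulfonyl group, which compound 4 does not have. Trimming the urea to an acetyl group is therefore expected to give a number 3 percentage points higher from compound 3 to compound 4 (within the scatter), nothing beyond the scatter. Compound 4 is estimated at 3%, between 0% and 12%.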

Compound 4, a percentage reported as inhibition, in the whole organism at one dose (the size of the read-out at that dose, not a potency): 8.6%
Estimate against measurement, compound 4: 5.6 percentage points below; the range from low to high includes it.
By their numbers in this assay, from the lowest: compounds 3, 2 and 4 (each within the scatter of the next); then compound 1.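

In this assay, trimming the urea to an acetyl group, with cyclohexylamino leaving and methyl entering on the carbonyl carbon, gives a number 8.6 percentage points higher from compound 3 to compound 4 (within the scatter), so at this dose the read-out does not separate the cyclohexyl-bearing urea from the much smaller acetyl group. Placing acetyl on the amine nitrogen instead of hydrogen gives a number 5.8 percentage points higher from compound 2 to compound 4 (within the scatter), while acetyl in place of phenylsulfonyl gives a number 16.6 percentage points lower from compound 1 to compound 4 (beyond the scatter), so among these four compounds only the phenylsulfonyl compound stands apart, now against a small acyl group as well as the free amine and the urea. Nothing available explains why the phenylsulfonyl group differs from the other three.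

As far as these compounds go, it remains open whether the sulfonyl link or the phenyl ring accounts for that difference; a methanesulfonyl group and a benzoyl group on the amine nitrogen would help separate the two. The single dose also gives no potency for any of these compounds.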